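The source may report more compounds than this note shows. Statements on the series, on what has been measured and on what is new or still open speak of the compounds shown alone.

In a functional assay on MKN-45 cells (Homo sapiens) for cytotoxicity, read by MTT assay, with a stated time of 72 h (on this read-out lower numbers stand for stronger inhibition and higher numbers for weaker inhibition), compound 3 `CCN(CC)CCNc1nc(-c2ccc(NC(=O)Nc3ccc(Cl)cc3Cl)cc2)nc2c(Cl)c(Cl)sc12` gives 1770 nM. Among the three measured compounds it stands second highest: its nearest neighbour is compound 2 `CCN(CC)CCNc1nc(-c2ccc(NC(=O)Nc3ccc(F)cc3)cc2)nc2c(Cl)c(Cl)sc12`, which in this assay gives 1370 nM, a gap within the scatter, while the furthest is compound 1 `Cc1ccc(NC(=O)Nc2ccc(-c3nc(NCCCN(C)C)c4sc(Cl)c(Cl)c4n3)cc2)cc1`, which gives 3700 nM, a gap beyond the scatter.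

Compound 4 `CCN(CC)CCNc1nc(-c2ccc(NC(=O)Nc3ccc(C)cc3)cc2)nc2c(Cl)c(Cl)sc12` differs from compound 3 by 4-methylphenyl in place of 2,4-dichlorophenyl on an amide-type nitrogen. Within the data shown here, one measured step bears directly on such a change of the aryl group on the urea: a 1.3-fold higher number from compound 2 to compound 3 (0.11 log units; within the scatter). Compound 1 carries the same 4-methylphenyl group as compound 4 but a different amine chain, so its value can only be compared loosely; it shows a higher number than compound 3.

Given that the measured aryl exchange stayed within the scatter, compound 4 is expected to land close to compound 3, with perhaps a slightly higher number, the expected step being a 1.3-fold higher number from compound 3 to compound 4 (0.11 log units; within the scatter). The estimate for compound 4 in this assay is 2300 nM, within a range of 1000 nM to 5300 nM.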

Compound 4, half-maximal inhibitory concentration: 1450 nM
For compound 4 the middle estimate is 1.6-fold (0.20 log units) above the measured one; measured number inside the range.
By their numbers in this assay, from the lowest: compounds 2, 4 and 3 (each within the scatter of the next); then compound 1.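

In this assay the position on the amide-type nitrogen proves tolerant: 4-methylphenyl in place of 2,4-dichlorophenyl gives a 1.2-fold lower number from compound 3 to compound 4 (0.09 log units; within the scatter) and methyl in place of fluoro on the aromatic carbon gives a 1.1-fold higher number from compound 2 to compound 4 (0.02 log units; within the scatter) so that compounds 2, 3 and 4 all lie within the scatter of each other. Among these compounds, the one new step beyond the scatter lies in the chain instead, where diethylamino in place of (dimethylamino)methyl gives a 2.6-fold lower number from compound 1 to compound 4 (0.41 log units; beyond the scatter) with the 4-methylphenyl group unchanged. The data shown offer no measured explanation for either finding.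

On these data alone, it remains open whether this tolerance extends to a methoxy group or a carboxylic acid on the phenyl ring, or to a pyridine ring in its place. As far as these compounds go, it also remains open how a morpholine at the chain end would compare with diethylamino.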